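This account rests on a few compounds, and the source may have more. Where it says the series, first, only, none or still open, it means among the compounds named here.

Measured compounds in an assay on cells for antagonist activity at transient receptor potential cation channel subfamily V member 1 (Homo sapiens), read by FLIPR and calcium flux, with a stated time of 6 min; on this read-out higher numbers stand for weaker inhibition and lower numbers for stronger inhibition: compound 1 `CCOc1nc(C(C)(C)C)ccc1CNC(=O)C(C)c1ccc(NS(C)(=O)=O)c(F)c1` gives 14.8 nM; compound 2 `CCCOc1nc(C(C)(C)C)ccc1CNC(=O)C(C)c1ccc(NS(C)(=O)=O)c(F)c1` gives 1.7 nM; compound 3 `CC(C)COc1nc(C(C)(C)C)ccc1CNC(=O)C(C)c1ccc(NS(C)(=O)=O)c(F)c1` gives 0.6 nM.

Compound 3 stands lowest of the three numbers: a 2.8-fold lower number from compound 2 to compound 3 (0.45 log units; beyond the scatter) and a 25-fold lower number from compound 1 to compound 3 (1.39 log units; beyond the scatter). Compound 4 `COCCCOc1nc(C(C)(C)C)ccc1CNC(=O)C(C)c1ccc(NS(C)(=O)=O)c(F)c1` differs from compound 3 by 2-methoxyethyl in place of isopropyl on a saturated chain carbon bound to an oxygen on an aromatic ring. Within the data shown here, the steps that bear on it are those along the alkoxy chain: an 8.7-fold lower number from compound 1 to compound 2 (0.94 log units; beyond the scatter) and a 2.8-fold lower number from compound 2 to compound 3 (0.45 log units; beyond the scatter), both lowering the number as the chain grows. Among the measured compounds shown here, compound 4 carries a chain of comparable length to that of compound 3, but with an ether oxygen in place of the branch, and no measured step covers that swap directly. The expectation is therefore a number near that of compound 3 or compound 2, with the change a 2.5-fold higher number from compound 3 to compound 4 (0.40 log units; beyond the scatter) estimated as small. Compound 4 is estimated at 1.5 nM, range 0.4 nM to 6 nM.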

Compound 4, inhibition constant: 5.6 nM
The estimate for compound 4 lay 3.7-fold (0.57 log units) below the measured number; the measured number falls inside the stated range.
By their numbers in this assay, from the lowest: compound 3; then compound 2; then compound 4; then compound 1.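

At this position, chain growth alone does not lower the number in this assay: adding methoxy to the chain gives the opposite of the earlier alkyl steps (a 3.3-fold higher number from compound 2 to compound 4 (0.52 log units; beyond the scatter)). Replacing isobutoxy with 3-methoxypropoxy raises the number (a 9.3-fold higher number from compound 3 to compound 4 (0.97 log units; beyond the scatter)), yet the ether chain still improves on the shortest alkoxy group (a 2.6-fold lower number from compound 1 to compound 4 (0.42 log units; beyond the scatter)). Nothing available accounts for these shifts. As far as these compounds go, whether the rise follows the ether oxygen itself or its place along the chain remains open. A longer chain ending in methoxy, or an amine in place of that oxygen, would help separate the two.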